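The source may hold more compounds than are shown below. What is called first, only, known or untested is meant among the compounds shown, and "the series" means these compounds.

Measured compounds:
Compound 1, `O=C1Nc2ccccc2C1CCCCN1CCN(c2cccc(Cl)c2)CC1`, gives 26 nM in an assay on membranes from frontal cortex for displacement of a labelled ligand from Adrenergic receptor alpha-1 (Rattus norvegicus), read by scintillation counting, with a stated time of 45 min; on this read-out higher numbers stand for weaker inhibition and lower numbers for stronger inhibition.
Compound 2, `O=C1Nc2ccccc2C1CCCCN1CCN(c2ccc(F)cc2)CC1`, gives 14 nM in this assay.

Compound 2 carries the lower of the two numbers, but the step of a 1.9-fold lower number from compound 1 to compound 2 (0.27 log units; within the scatter) leaves it indistinguishable from compound 1. Compound 3, `O=C1Nc2ccccc2C1CCCCN1CCN(c2ccccn2)CC1`, has not yet been measured; its change from compound 2 is pyridin-2-yl in place of 4-fluorophenyl on an amine nitrogen in a ring. Among the compounds with values here, the only step that touches this position is the one from compound 1 to compound 2, a swap between two carbon-only rings with halogen that stayed within the scatter. Nothing measured speaks to a ring with a hetero atom at this place, so the expectation rests on that single indifferent step and is set with wide bounds. Compound 3 is therefore estimated to give about 40 nM in this assay, with a plausible range of 10 nM to 160 nM, the expected step of a 2.9-fold higher number from compound 2 to compound 3 (0.46 log units; beyond the scatter) being small and of uncertain direction.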

Compound 3, inhibition constant: 130 nM
The estimate for compound 3 lay 3.3-fold (0.51 log units) below the measured number; the measured number falls inside the stated range.
By their numbers in this assay, from the lowest: compounds 2 and 1 (each within the scatter of the next); then compound 3.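

In this assay, within the data shown here, the change to pyridin-2-yl gives a 9.3-fold higher number from compound 2 to compound 3 (0.97 log units; beyond the scatter) and, against the other halogen-bearing ring, a 5.0-fold higher number from compound 1 to compound 3 (0.70 log units; beyond the scatter) as well, so this is the first change at the amine nitrogen in a ring that reaches beyond the scatter. The position is therefore not indifferent to the ring it carries: 4-fluorophenyl and 3-chlorophenyl cannot be told apart here, whereas the ring with a hetero atom stands apart from both. No measurement shown accounts for this difference.

The three compounds cannot separate the entry of the ring nitrogen from the loss of the halogen, which unsubstituted phenyl would help to resolve. Going by these compounds, whether the nitrogen's place in the ring matters remains open too, as pyridin-3-yl or pyrimidin-2-yl would show.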